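The compounds below may be only part of what the source reports. "The series", "measured", "known", "first", "only" and "open" are said of these compounds alone.

Compound 1 `Nc1nc(N)c2cc(CSC(=S)N3CCN(c4ccccc4)CC3)ccc2n1`: 2950 nM
Compound 2 `CC(=O)c1ccc(N2CCN(C(=S)SCc3ccc4nc(N)nc(N)c4c3)CC2)cc1`: 2490 nM

Both compounds were tested in a functional assay on MCF7 cells (Homo sapiens) for antiproliferative activity, read by MTT assay, with a stated time of 72 h; on this read-out higher numbers stand for weaker inhibition and lower numbers for stronger inhibition. Compound 2 gives 2490 nM and stands level with compound 1 once the usual scatter of repeated measurements is taken into account.

The next compound to consider is compound 3 `Nc1nc(N)c2cc(CSC(=S)N3CCN(c4ccc(C(F)(F)F)cc4)CC3)ccc2n1`, which keeps the shared core. It carries trifluoromethyl in place of acetyl on an aromatic carbon, para to a large group (trifluoromethyl in place of acetyl on an aromatic carbon).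

Within the data shown here, only one measured step bears on this change: a 1.2-fold lower number from compound 1 to compound 2 (0.07 log units; within the scatter). That step put acetyl in place of hydrogen at the same spot and stayed within the scatter, so this spot has so far tolerated two different substituents with no measurable change. Among the measured compounds shown here, it is thin evidence, as no measured compound carries trifluoromethyl. Even so, it gives no reason to expect a shift in either direction, and no step beyond the scatter is expected in this assay.

The expected step is a 1.0-fold higher number from compound 2 to compound 3 (0.00 log units; within the scatter).

For compound 3 the estimated value is 2500 nM, with an expected range from 1100 nM to 5500 nM.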

Compound 3, half-maximal inhibitory concentration: 7400 nM
The estimate for compound 3 lay 3.0-fold (0.47 log units) below the measured number; the measured number lies above the stated range.
By their numbers in this assay, from the lowest: compounds 2 and 1 (each within the scatter of the next); then compound 3.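

Until now this spot on the aromatic ring looked indifferent to what sat on it, but trifluoromethyl changes that picture in this assay: replacing acetyl gives a 3.0-fold higher number from compound 2 to compound 3 (0.47 log units; beyond the scatter), and replacing plain hydrogen gives a 2.5-fold higher number from compound 1 to compound 3 (0.40 log units; beyond the scatter). The spot therefore does respond to its substituent, and the level standing of hydrogen and acetyl does not carry over to every group, with compound 3 the weakest of the three on this read-out. Nothing in the available data accounts for why trifluoromethyl behaves differently from the other two groups here.

Three compounds, carrying only hydrogen, acetyl and trifluoromethyl at this spot, cannot show which feature of a substituent governs the number, or whether the loss of activity is particular to trifluoromethyl. An amine, a methoxy group, a carboxylic acid or a single fluorine at the same spot would help show whether trifluoromethyl stands alone or whether hydrogen and acetyl are the unusual pair.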